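The source may report more compounds than this note shows. Statements on the series, on what has been measured and on what is new or still open speak of the compounds shown alone.

Measured so far in a functional assay on EKVX cells (Homo sapiens) for antiproliferative activity, read by sulforhodamine B assay, with a stated time of 48 h; on this read-out higher numbers stand for weaker inhibition of growth and lower numbers for stronger inhibition of growth
compound 1 `O=C(NCCCNc1cc(-c2cn(-c3ccccc3)nc2-c2cccc(O)c2)ccn1)Nc1ccc(F)cc1` gives 9510 nM
compound 2 `O=C(NCCCNc1cc(-c2cn(-c3ccccc3)nc2-c2cccc(O)c2)ccn1)Nc1cccc(C(F)(F)F)c1` gives 8450 nM

For the measured compounds named here, compound 1 has only one neighbour on these numbers, and the two values lie within the scatter of each other. Going by the values given here, the single measured step is a 1.1-fold lower number from compound 1 to compound 2 (0.05 log units; within the scatter), with 3-(trifluoromethyl)phenyl in place of 4-fluorophenyl on an amide-type nitrogen. Unmeasured compound 3 `COc1cccc(-c2nn(-c3ccccc3)cc2-c2ccnc(NCCCNC(=O)Nc3ccc(F)cc3)c2)c1` differs from compound 1 by methyl in place of hydrogen on an oxygen on an aromatic ring, which turns 3-hydroxyphenyl into 3-methoxyphenyl. The measured step lies at another place, so no data bear directly on this change. Going by these compounds, with no measured guide, no shift beyond the scatter is expected in this assay and the direction stays open. The estimated step is a 1.3-fold higher number from compound 1 to compound 3 (0.10 log units; within the scatter) and it is expected to carry little weight. For compound 3 the expected value is 12000 nM, with an estimated range from 4500 nM to 32000 nM as its bounds.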

Compound 3, concentration for total growth inhibition: > 37000 nM
Compound 3 ended at the assay's limit; the forecaster's own chance of this, stated with the estimate: 10%; middle value at least 3.0-fold (0.48 log units) away from the limit.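

In this assay compound 3 gives > 37000 nM, which is a limit of the assay and not a number: the limit of > 37000 nM in this assay, at which 1 of the 3 values shown sits.

Hydroxy to methoxy on the aromatic ring brings an at least 3.8-fold higher number from compound 1 to compound 3 (0.59 log units; beyond the scatter), the first change in these compounds to pass the scatter, whereas the swap on the amide-type nitrogen gave a 1.1-fold lower number from compound 1 to compound 2 (0.05 log units; within the scatter). Among the three compounds, the oxygen of the 3-hydroxyphenyl group is therefore the one place where a change shifts the read-out, and the shift runs towards weaker inhibition of growth.

The compounds shown leave open whether the step follows from the hydrogen leaving the oxygen or from the methyl entering, and how large it really is. An amino group or a fluorine at this place, or an ethoxy group, would bear on that question.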